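The source may hold more compounds than are shown below. What is called first, only, known or untested is meant among the compounds shown, and "the series" means these compounds.

The series shares one core, seen in compound 1 `COc1cc(-c2nn(-c3cccc(NC(=O)Nc4cccc(C(F)(F)F)c4)c3)cc2-c2ccncc2)ccc1Cl`. In a functional assay on MDA-MB-468 cells (Homo sapiens) for inhibition, read by sulforhodamine B assay, with a stated time of 48 h (a lower number here means a stronger inhibitor, a higher number a weaker inhibitor), compound 1 gives 600 nM. Compound 2 `COc1cc(-c2nn(-c3cccc(NC(=O)c4ccc(Cl)c(C(F)(F)F)c4)c3)cc2-c2ccncc2)ccc1Cl` gives 3690 nM in this assay, and compound 3 `COc1cc(-c2nn(-c3cccc(NC(=O)Nc4ccc(Cl)c(C(F)(F)F)c4)c3)cc2-c2ccncc2)ccc1Cl` gives 830 nM in this assay. Compound 3 thus stands second highest of the three numbers: its nearest neighbour is compound 1, a gap within the scatter, and its furthest is compound 2, with a 4.4-fold lower number from compound 2 to compound 3 (0.65 log units; beyond the scatter).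

Compound 4 `COc1cc(-c2nn(-c3cccc(NC(=O)c4ccccc4)c3)cc2-c2ccncc2)ccc1Cl` has not yet been measured. It differs from compound 3 in one place: phenyl in place of (4-chloro-3-(trifluoromethyl)phenyl)amino on a carbonyl carbon. Among the measured compounds shown here, two measured steps bear on this exchange at the carbonyl carbon. Putting a ring bound directly to the carbonyl carbon in place of an amino-linked ring gave a 6.2-fold higher number from compound 1 to compound 2 (0.79 log units; beyond the scatter), and the reverse exchange gave a 4.4-fold lower number from compound 2 to compound 3 (0.65 log units; beyond the scatter). Both point the same way: the ring bound straight to the carbonyl carbon goes with a higher number. For the measured compounds named here, the step to compound 4 also removes chloro and trifluoromethyl from that ring, for which no measured pair exists here, so only the carbonyl-side exchange serves as a guide. A step in this assay of roughly the size seen in those two pairs, towards a higher number, is therefore expected, a 4.8-fold higher number from compound 3 to compound 4 (0.68 log units; beyond the scatter). Compound 4 is accordingly expected to give about 4000 nM, within 1500 nM to 11000 nM.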

Compound 4, half-maximal inhibitory concentration: 350 nM
Compound 4: middle estimate off by 11-fold (1.06 log units), on the high side, outside the stated range (below it).
By their numbers in this assay, from the lowest: compounds 4, 1 and 3 (each within the scatter of the next, the first and the last beyond it); then compound 2.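

In this assay, the ring bound straight to the carbonyl carbon does not by itself go with a higher number: with phenyl there instead of 4-chloro-3-(trifluoromethyl)phenyl, the series shows an 11-fold lower number from compound 2 to compound 4 (1.02 log units; beyond the scatter), so the earlier link rests on compound 2 alone and compound 4 goes against it. The chloro and trifluoromethyl groups and the amino link are not needed for activity at this position, as the exchange of (4-chloro-3-(trifluoromethyl)phenyl)amino for phenyl gives a 2.4-fold lower number from compound 3 to compound 4 (0.38 log units; beyond the scatter), even though it removes heavy atoms from that group, and the comparison with the other urea gives a 1.7-fold lower number from compound 1 to compound 4 (0.23 log units; within the scatter), which leaves compound 4 and compound 1 inseparable. Nothing available explains these steps.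

Still open, going by these compounds, is whether the step from compound 2 to compound 4 belongs to the chloro, to the trifluoromethyl or only to the two together, and whether an unsubstituted phenylamino on the carbonyl carbon would read like the substituted ureas or like compound 4. Also open, on these data alone, is how the phenyl ring of compound 4 would tolerate a methoxy group, a dimethylamino group or a carboxylic acid.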